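This account rests on a few compounds, and the source may have more. Where it says the series, first, only, none or still open, it means among the compounds named here.

Compound 1, `Cc1ccc(C(=O)Nc2ccc(CNC(=O)OCc3cccnc3)cc2)c(N2CCCC2)c1`, gives > 100000 nM in a toxicity assay on WI-38 cells (Homo sapiens) for inhibition, read by MTT assay, with a stated time of 72 h (on this read-out higher numbers stand for weaker inhibition and lower numbers for stronger inhibition), which is a limit of the assay and not a number. Compound 2, `O=C(NCc1ccc(NC(=O)c2cc(Cl)ccc2N2CCCC2)cc1)OCc1cccnc1`, gives > 100000 nM in this assay, again a limit. Compound 3, `Cc1ccc(N2CCCC2)c(C(=O)Nc2ccc(CNC(=O)OCc3cccnc3)cc2)c1`, gives 40600 nM in this assay.

Within the data shown here, compound 3 therefore stands as the only compound with a plain number; the other two values sit at the limit of > 100000 nM in this assay, at which 2 of the 3 values shown sit. Compound 4, `O=C(NCc1ccc(NC(=O)c2cc(Br)ccc2N2CCCC2)cc1)OCc1cccnc1`, has not yet been measured. It differs from compound 3 in one place: bromo in place of methyl on an aromatic carbon.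

Among the measured compounds shown here, the one measured step that bears on this is the reverse kind of change: an at least 2.4-fold lower number from compound 2 to compound 3 (0.39 log units; beyond the scatter). There, a halogen gave way to methyl and the number fell from the limit to a measurable value. Replacing methyl with bromo runs the other way, so the number for compound 4 is expected to rise by about a 2.2-fold higher number from compound 3 to compound 4 (0.35 log units; beyond the scatter), very possibly back to the limit. Compound 4 is estimated at 90000 nM, with a likely range from 25000 nM to 300000 nM.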

Compound 4, half-maximal inhibitory concentration: > 100000 nM
Compound 4: no number, only a limit; the forecaster's own chance of this, stated with the estimate: 50%; middle value at least 1.1-fold (0.04 log units) away from the limit.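

Bromo in place of methyl, para to a pyrrolidin-1-yl group, gives an at least 2.4-fold higher number from compound 3 to compound 4 (0.39 log units; beyond the scatter), so the loss of a plain number in this assay now holds for a second halogen and not for chloro alone. The step between compound 2 and compound 4 cannot be read, as both values are limits, so the two halogens cannot be ranked against each other. At this position, methyl in compound 3 is the only one of the three groups shown to give a plain number, and the series now gathers at one end of the scale: the limit of > 100000 nM in this assay, at which 3 of the 4 values shown sit.

From the compounds shown here alone, how far compound 2 and compound 4 lie beyond the limit remains unknown. Also open, going by these compounds, is whether a different group at this position, such as an amine, a methoxy group or a plain hydrogen, would give a plain number as methyl does.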